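A Repeated Methyl Addition Across Two Related Cores

The source may hold more compounds than are shown below. What is called first, only, known or untested is meant among the compounds shown, and "the series" means these compounds.

Compound 1 `Cc1ccccc1Oc1ccc(C#N)cc1S(=O)(=O)NC(=O)NC(C)C` — 8680 nM
Compound 2 `Cc1ccccc1Oc1ccc(C#N)cc1S(=O)(=O)NC(=O)NC(C)(C)C` — 3690 nM
Compound 3 `Cc1ccccc1Nc1ccc(C#N)cc1S(=O)(=O)NC(=O)NC(C)C` — 7240 nM

Of the compounds shown here, three have been measured in a functional assay on HEK293 cells for antagonist activity at thromboxane A2 receptor (Homo sapiens), read by fluorescence and calcium flux; a higher number here means a weaker inhibitor, a lower number a stronger inhibitor. Compound 1 and compound 3 share most of their structure and differ only in that compound 3 carries (2-methylphenyl)amino in place of 2-methylphenoxy on an aromatic carbon. This exchange of cores made little difference: a 1.2-fold lower number from compound 1 to compound 3 (0.08 log units; within the scatter), so the two values cannot be told apart.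

Going by the values given here, the one change that moved the read-out is seen between compound 1 and compound 2, where compound 2 has methyl in place of hydrogen on a saturated chain carbon bound to an amide-type nitrogen and two saturated chain carbons. Here a 2.4-fold lower number from compound 1 to compound 2 (0.37 log units; beyond the scatter).

Compound 4 `Cc1ccccc1Nc1ccc(C#N)cc1S(=O)(=O)NC(=O)NC(C)(C)C` has not yet been measured. It stands to compound 3 exactly as compound 2 stands to compound 1: it carries methyl in place of hydrogen on a saturated chain carbon bound to an amide-type nitrogen and two saturated chain carbons. The place of the change is described in the same words in both cases, so this is the same change, made on the core of compound 3 instead of the core of compound 1.

Among the compounds with values here, since the two cores behaved alike in this assay, the expectation for compound 4 rests on the only earlier instance of this change, the step of a 2.4-fold lower number from compound 1 to compound 2 (0.37 log units; beyond the scatter), and it is estimated that the new step will be of similar size, a 2.4-fold lower number from compound 3 to compound 4 (0.38 log units; beyond the scatter). With a single precedent, a wide range is kept. Compound 4 is therefore expected to give about 3000 nM in this assay, most likely between 1400 nM and 6500 nM.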

Compound 4, half-maximal inhibitory concentration: 2750 nM
The estimate for compound 4 lay 1.1-fold (0.04 log units) above the measured number; the range from low to high includes it.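

In this assay, going from isopropyl to tert-butyl on the core of compound 3 gave a 2.6-fold lower number from compound 3 to compound 4 (0.42 log units; beyond the scatter), and this step matches the one seen earlier on the core of compound 1: the same change on two cores in this assay, a 2.4-fold lower number (0.37 log units; beyond the scatter) from compound 1 to compound 2 and a 2.6-fold lower number (0.42 log units; beyond the scatter) from compound 3 to compound 4, 1.1-fold (0.05 log units) apart, within the scatter of two such steps

The exchange of 2-methylphenoxy for (2-methylphenyl)amino, now made with tert-butyl in place, gave a 1.3-fold lower number from compound 2 to compound 4 (0.13 log units; within the scatter), so it again could not be told from no change, just as it could not with isopropyl: the same change on two cores in this assay, a 1.2-fold lower number (0.08 log units; within the scatter) from compound 1 to compound 3 and a 1.3-fold lower number (0.13 log units; within the scatter) from compound 2 to compound 4, 1.1-fold (0.05 log units) apart, within the scatter of two such steps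

Within these four compounds, the two changes therefore behave independently, and the gain from tert-butyl carries from one core to the other, but this rests on a single pair on each core in one assay and does not show that it would hold on a core outside this set or explain why the step occurs.

The compounds shown leave open whether a cyclohexyl group or a longer chain in place of tert-butyl would extend the same step. They also leave open whether a carboxylic acid in place of the nitrile, or a sulfur atom in place of the oxygen or the amino nitrogen, would leave the two changes as independent as they appear here.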